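Nitro in place of methyl in compound 2

The source may hold more compounds than are shown below. What is called first, only, known or untested is meant among the compounds shown, and "the series" means these compounds.

Going by the values given here, in an assay for inhibition of kynurenine 3-monooxygenase (Rattus norvegicus) (on this read-out lower numbers stand for stronger inhibition and higher numbers for weaker inhibition), compound 2 `COC(=O)C(=O)/C=C(\O)c1ccc(Cl)c(C)c1` gives 4900 nM, the higher of the two numbers so far; compound 1 `COC(=O)C(=O)/C=C(\O)c1ccc(Cl)c(Cl)c1` gives 1900 nM. Among the compounds with values here, the only step at this position is a 2.6-fold higher number from compound 1 to compound 2 (0.41 log units; beyond the scatter), which is modest. Compound 3 `COC(=O)C(=O)/C=C(\O)c1ccc(Cl)c([N+](=O)[O-])c1` differs from compound 2 by nitro in place of methyl on an aromatic carbon. Within the data shown here, no measured step involves a nitro group, so only compound 1 offers a comparator at this position, with the lower number. The expected step is therefore a 2.0-fold lower number from compound 2 to compound 3 (0.29 log units; within the scatter), downward but small, near the edge of the scatter. Compound 3 is estimated at 2500 nM, between 800 nM and 8000 nM.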

Compound 3, half-maximal inhibitory concentration: 11200 nM
Compound 3: middle estimate off by 4.5-fold (0.65 log units), on the low side, and the stated range ends below it.
By their numbers in this assay, from the lowest: compound 1; then compound 2; then compound 3.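

At this position, ortho to a chloro group, replacing methyl does not move the number in one direction in this assay: nitro gives a 2.3-fold higher number from compound 2 to compound 3 (0.36 log units; beyond the scatter), the opposite direction to chloro. Nitro also falls well short of chloro, with a 5.9-fold higher number from compound 1 to compound 3 (0.77 log units; beyond the scatter), so chloro holds the lowest number of the three groups. Nothing available explains why nitro and chloro differ here.

On these data alone, whether an amine, a nitrile or a bromo group at this position would match or improve on chloro remains open. Also open, as far as these compounds go, is whether this order of the three groups holds with another group in place of the neighbouring chloro.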